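A few compounds are considered here, and "the series" means these few. Any claim that something is new, unique, unknown or untested is made for them only; others in the source may bear on it.

In a functional assay on HL-60 cells (Homo sapiens) for inhibition (on this read-out lower numbers stand for stronger inhibition and higher numbers for weaker inhibition), compound 1, `COc1cc(/C=C/c2ccc(N(C)C)c(N)c2)cc(OC)c1OC`, gives 1520 nM. Compound 2, `COc1cc(/C=C/c2cn(C(C)=O)c3ccccc23)cc(OC)c1OC`, reads > 5000 nM in this assay, and this is a limit of the assay, not a number. Compound 3, `COc1cc(/C=C\c2cn(C(C)=O)c3ccccc23)cc(OC)c1OC`, differs from compound 2 as follows: the two compounds have the same atoms and bonds and differ only in configuration as drawn: 1 of 1 stereo elements differ; a double bond is drawn E in compound 2 and Z in compound 3. Among the measured compounds shown here, no measured pair isolates this change, so the expectation is tentative and the range wide. The expected size of the change is an at least 12-fold lower number from compound 2 to compound 3 (1.09 log units; beyond the scatter), in the direction of stronger inhibition. For compound 3 the estimated value is 400 nM, with an expected range from 40 nM to 5000 nM.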

Compound 3, half-maximal inhibitory concentration: 2850 nM
Beside the measured number, compound 3's estimate is 7.1-fold (0.85 log units) below it, and the stated range covers the measured number.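

Compound 2 reads > 5000 nM in this assay, which is a limit of the assay and not a number. On these data alone, the change from an E to a Z double bond therefore has only a floor, an at least 1.7-fold lower number from compound 2 to compound 3 (0.24 log units; that floor lies within the scatter), and its true size remains unknown. Any real difference between this pair can be assigned to the double bond alone because nothing else separates them: the fact that compounds 2 and 3 differ only in the configuration as drawn

As far as these compounds go, whether the Z double bond gives a lower number on any other core remains open. So does the effect of a sulfonamide or a longer acyl chain in place of the acetyl group.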